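This account rests on a few compounds, and the source may have more. Where it says the series, first, only, none or still open, it means among the compounds named here.

In a functional assay on CAL-27 cells (Homo sapiens) for cytotoxicity, read by MTT assay, with a stated time of 72 h (a higher number here means a weaker inhibitor, a lower number a stronger inhibitor), two compounds on a shared core have been measured so far. Compound 1 `Cc1cc(C)cc(C(=O)N(CCCCCC(=O)Nc2ccccc2N)CC(=O)NCc2ccccc2)c1` gives 13700 nM as its value, and compound 2 `Cc1cc(C)cc(CNC(=O)CN(CCCCCC(=O)Nc2ccccc2N)C(=O)c2cc(C)cc(C)c2)c1` gives 19300 nM as its value, so compound 2 stands level with compound 1 within the scatter of repeated measurements. Compound 3 `COc1ccc(CNC(=O)CN(CCCCCC(=O)Nc2ccccc2N)C(=O)c2cc(C)cc(C)c2)cc1` has not yet been measured. It carries 4-methoxyphenyl in place of 3,5-dimethylphenyl on a saturated chain carbon bound to an amide-type nitrogen, and the change 4-methoxyphenyl in place of 3,5-dimethylphenyl on a saturated chain carbon bound to an amide-type nitrogen touches nothing else in the structure. Among the measured compounds shown here, with a 1.4-fold higher number from compound 1 to compound 2 (0.15 log units; within the scatter) as the only measured step at this place, where 3,5-dimethylphenyl replaced phenyl, no step beyond the scatter is expected in this assay and no direction can be named. The estimated change is a 1.2-fold lower number from compound 2 to compound 3 (0.08 log units; within the scatter) in size. For compound 3 the expected value is 16000 nM with an estimated range from 7000 nM to 38000 nM around it.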

Compound 3, half-maximal inhibitory concentration: 17400 nM
Estimate against measurement, compound 3: 1.1-fold (0.04 log units) below; measured number inside the range.
By their numbers in this assay, from the lowest: compounds 1, 3 and 2 (each within the scatter of the next).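

Exchanging 3,5-dimethylphenyl for 4-methoxyphenyl on a saturated chain carbon bound to an amide-type nitrogen gives a 1.1-fold lower number from compound 2 to compound 3 (0.05 log units; within the scatter) in this assay, and adding methoxy to the plain phenyl ring gives a 1.3-fold higher number from compound 1 to compound 3 (0.10 log units; within the scatter) in the same test. This place has now carried phenyl, 3,5-dimethylphenyl and 4-methoxyphenyl with no step beyond the scatter, even though 4-methoxyphenyl brings a hydrogen-bond acceptor and 3,5-dimethylphenyl has none. No measurement is available that could account for this lack of separation.

The compounds shown leave open whether an amine, a carboxylic acid or a longer chain at this place would move the number beyond the scatter. They also leave open how changes elsewhere on the shared core would register in this test.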